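Working notes: step from compound 3 to compound 4

The source may report more compounds than this note shows. Statements on the series, on what has been measured and on what is new or still open speak of the compounds shown alone.

Measured so far:
- compound 1, `O=C1C(Cl)=C(Cl)C(=O)c2ncccc21`, in a functional assay on HL-60 cells (Homo sapiens) for antiproliferative activity, read by MTT assay, with a stated time of 48 h; a higher number here means a weaker inhibitor, a lower number a stronger inhibitor: 31800 nM
- compound 2, `O=C1C(NC(c2ccccc2)c2ccccc2)=C(Cl)C(=O)c2ncccc21`, in this assay: 2450 nM
- compound 3, `CS(=O)(=O)C1=C(N)C(=O)c2cccnc2C1=O`, in this assay: 4530 nM
- compound 4, `C[S+]([O-])C1=C(N)C(=O)c2cccnc2C1=O`, not yet measured

Compound 3 holds the second highest of the three numbers. Its nearest neighbour is compound 2, whose number is within the scatter of that of compound 3, so nothing can be said of an order between these two. Compound 1 gives the highest number, and the gap from compound 3 to compound 1 lies beyond the scatter.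

Compound 4 differs from compound 3 in one place: a group of 3 heavy atoms (1 carbon, 1 oxygen, 1 sulfur; no ring) in place of a group of 4 heavy atoms (1 carbon, 2 oxygen, 1 sulfur; no ring), on a double-bonded ring carbon. Among the compounds with values here, no measured pair shows what this change does in this assay, so the expectation rests on compound 3 alone. The step is expected to be small, most likely none beyond the scatter, with no firm direction. The estimate for compound 4 in this assay is 5000 nM, within 1500 nM to 16000 nM, which means an expected step of a 1.1-fold higher number from compound 3 to compound 4 (0.04 log units; within the scatter).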

Compound 4, half-maximal inhibitory concentration: 1300 nM
For compound 4 the middle estimate is 3.8-fold (0.59 log units) above the measured one, outside the stated range (below it).
By their numbers in this assay, from the lowest: compounds 4, 2 and 3 (each within the scatter of the next, the first and the last beyond it); then compound 1.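

In this assay, a group of 3 heavy atoms (1 carbon, 1 oxygen, 1 sulfur) in place of methylsulfonyl, on the double-bonded ring carbon next to the ring atom that bears an amino group, gives a 3.5-fold lower number from compound 3 to compound 4 (0.54 log units; beyond the scatter) on the shared core. Within the data shown here, this pair is the first to differ in one place, and it shows that this position responds to a change confined to the sulfur-bearing group, with one oxygen fewer enough to carry the step beyond the scatter. Nothing at hand accounts for the step.

Going by these compounds, whether the step holds without the amino group, or with another group in its place, remains open. Also open, on these data alone, is whether a methylthio group, or a longer chain on the sulfur, would extend the step or reverse it.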